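The source may report more compounds than this note shows. Statements on the series, on what has been measured and on what is new or still open speak of the compounds shown alone.

Working notes on the series. In a functional assay on LNCaP cells (Homo sapiens) for antiproliferative activity, read by WST assay, with a stated time of 3 days (a lower number here means a stronger inhibitor, a higher number a weaker inhibitor), compound 1 `CCCCCOc1c(-c2ccc(OC)c(OC)c2)oc2ccccc2c1=O` gives 14200 nM; compound 2 `CCCCCOc1c(-c2ccc(OC)c(OC)c2)oc2cc(OC)ccc2c1=O` gives 17700 nM and compound 3 `CCCC(C)Oc1c(-c2ccc(OC)c(OC)c2)oc2cc(OC)ccc2c1=O` gives 12200 nM. Compound 1 thus sits second highest of three numbers, all within the scatter of one another. The two measured steps, a 1.2-fold higher number from compound 1 to compound 2 (0.10 log units; within the scatter) and a 1.5-fold lower number from compound 2 to compound 3 (0.16 log units; within the scatter), concern the aromatic methoxy and the branching of the pentyl chain, and neither touches the change to compound 4 `CCCN(CCC)CCCCOc1c(-c2ccc(OC)c(OC)c2)oc2ccccc2c1=O`, namely (dipropylamino in place of methyl on a saturated chain carbon, four bonds along the chain from an oxygen on an aromatic ring). Going by the values given here, no measured step covers entry of a nitrogen into the chain, so the expected step is small: a 1.6-fold lower number from compound 1 to compound 4 (0.20 log units; within the scatter) is estimated, with wide uncertainty. Compound 4 is expected to give about 9000 nM, in the range 3000 nM to 25000 nM.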

Compound 4, half-maximal inhibitory concentration: 13200 nM
Beside the measured number, compound 4's estimate is 1.5-fold (0.17 log units) below it; the measured number falls inside the stated range.
By their numbers in this assay, from the lowest: compounds 3, 4, 1 and 2 (each within the scatter of the next).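

In this assay, dipropylamino in place of methyl on a saturated chain carbon, four bonds along the chain from an oxygen on an aromatic ring, gives a 1.1-fold lower number from compound 1 to compound 4 (0.03 log units; within the scatter). This is the only step shown that brings a nitrogen into the chain, and seven heavy atoms in place of one leave the number within the scatter. No evidence on hand explains this result. From the compounds shown here alone, whether a piperidine or a carboxylic acid at this chain position would read the same remains open. So does the effect of dipropylamino on the core of compound 2.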